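The compounds below may be only part of what the source reports. "The series", "measured", "known", "first", "only" and "open" are said of these compounds alone.

Measured compounds:
compound 1 `CC[C@H]1OC(=O)[C@H](C)[C@@H](O[C@H]2C[C@@](C)(OC)[C@@H](O)[C@H](C)O2)[C@H](C)[C@@H](O[C@@H]2O[C@H](C)C[C@H](N(C)C)[C@H]2O)[C@](C)(O)C[C@@H](C)CN(C)[C@H](C)[C@@H](OCCCNC(=O)c2c(C)nn(C)c2Cl)[C@]1(C)O`: in a physicochemical assay for lipophilicity, read by HPLC, measured as chromatographic lipophilicity, at pH 7.4 (a higher number here means a more lipophilic compound, a lower number a more polar compound), compound 1 gives 3.01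
compound 2 `CC[C@H]1OC(=O)[C@H](C)[C@@H](O)[C@H](C)[C@@H](O[C@@H]2O[C@H](C)C[C@H](N(C)C)[C@H]2O)[C@](C)(OC)C[C@@H](C)/C(=N\O)[C@H](C)[C@@H](O)[C@]1(C)O`: compound 2 gives 2.31
compound 3 `CCCCCCCC(=O)NCCCO[C@@H]1[C@@H](C)C(=O)[C@H](C)C[C@@](C)(OC)[C@H](O[C@@H]2O[C@H](C)C[C@H](N(C)C)[C@H]2O)[C@@H](C)[C@H](O[C@H]2C[C@@](C)(OC)[C@@H](O)[C@H](C)O2)[C@@H](C)C(=O)O[C@H](CC)[C@@]1(C)O`: compound 3 gives 5.07

Compound 1 stands second highest of the three; compound 2 sits lower by a gap beyond the scatter, compound 3 higher by a wider gap, also beyond the scatter. Compound 4 `CC[C@H]1OC(=O)[C@H](C)[C@@H](O[C@H]2C[C@@](C)(OC)[C@@H](O)[C@H](C)O2)[C@H](C)[C@@H](O[C@@H]2O[C@H](C)C[C@H](N(C)C)[C@H]2O)[C@](C)(O)C[C@@H](C)CN(C)[C@H](C)[C@@H](OCCCNC(C)=O)[C@]1(C)O` differs from compound 1 in one place: methyl in place of 5-chloro-1,3-dimethyl-1H-pyrazol-4-yl on a carbonyl carbon. Among the measured compounds shown here, no measured pair shows this change directly, so the size of the step rests on the count alone: the leaving group carries a chlorine and an aromatic ring, the entering methyl is one heavy atom. A drop in this assay beyond the scatter is expected. The expected step from compound 1 to compound 4 is a number 1.01 log units lower from compound 1 to compound 4 (beyond the scatter). Compound 4 is estimated at 2, with a range from 1.5 to 2.5.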

Compound 4, distribution coefficient: 2.41
Compound 4: middle estimate off by 0.41 log units, on the low side; the measured number falls inside the stated range.
By their numbers in this assay, from the lowest: compounds 2 and 4 (each within the scatter of the next); then compound 1; then compound 3.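

In this assay the step of a number 0.60 log units lower from compound 1 to compound 4 (beyond the scatter) comes from methyl in place of 5-chloro-1,3-dimethyl-1H-pyrazol-4-yl on a carbonyl carbon. Among the compounds shown here, it is the first one-place comparison, and it shows that this position registers the exchange in this read-out. Nothing measured accounts for the size of the step.

This single step cannot separate the share of the chlorine from that of the aromatic ring. On these data alone, how a phenyl group or a carboxylic acid at this carbonyl carbon would stand in this assay remains open.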